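Boc-Amide Cap Exchanged for Benzoyl on a Tellurium Chain

A few compounds are considered here, and "the series" means these few. Any claim that something is new, unique, unknown or untested is made for them only; others in the source may bear on it.

Compound 1 `COc1ccc(N(CC(=O)NCCC[Te]c2ccccc2)C(=O)CNC(=O)OC(C)(C)C)cc1` was examined in a functional assay on T47D cells (Homo sapiens) for inhibition, with a stated time of 48 h; on this read-out lower numbers stand for higher toxicity in this test and higher numbers for lower toxicity in this test. In this assay compound 1 gives < 100000 nM, which is a limit of the test and not a number. Compound 2 `CC1=C(SCCC(=O)OCC(=O)NCCC[Te]c2ccccc2)C(=O)c2ccccc2C1=O` was run in the same test. In this assay compound 2 gives < 100000 nM, again only a limit. Both recorded values sit at the limit of < 100000 nM in this assay, at which 2 of the 2 values shown sit, so compound 1 cannot be ranked against compound 2 on these numbers. Compound 3 `COc1ccc(N(CC(=O)NCCC[Te]c2ccccc2)C(=O)c2ccccc2)cc1` has not yet been measured in this assay. It differs from compound 1 by phenyl in place of ((tert-butoxycarbonyl)amino)methyl on a carbonyl carbon. For the measured compounds named here, no pair of measured compounds shows what such an exchange does in this assay, so the expected step is small and without a clear direction beyond the scatter, estimated as a step that the limit leaves unreadable from compound 1 to compound 3. Compound 3 is therefore expected near 30000 nM, within 5000 nM to 100000 nM, and the test will most likely again report only a limit.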

Compound 3, concentration lethal to 50% of the cells: < 100000 nM
Compound 3 was reported as a limit (the forecaster's own chance of this, stated with the estimate: 70%); the middle value does not contradict the limit.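

In this assay, compound 1 and compound 3 are both recorded only as limits, so no step can be read between them: the limit of < 100000 nM in this assay, at which 3 of the 3 values shown sit.

On these data alone, what phenyl in place of ((tert-butoxycarbonyl)amino)methyl does in this assay, and how compound 1, compound 2 and compound 3 rank against one another, remains open.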